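The compounds below may be only part of what the source reports. "The series", "measured", "known", "first", "only" and "open" are said of these compounds alone.

Measured compounds:
compound 1, `CCCCCC(=O)Nc1ccc(S(=O)(=O)Oc2ccccc2C(C)C)cc1`, 6300 nM
compound 2, `CC(C)c1ccccc1OS(=O)(=O)c1ccc(NC(=O)CCCl)cc1`, 6500 nM

Of the two numbers in a functional assay on HT-1080 cells (Homo sapiens) for antiproliferative activity, read by sulforhodamine B assay, with a stated time of 48 h (on this read-out lower numbers stand for stronger inhibition and higher numbers for weaker inhibition), compound 2 holds the higher one, yet the step of a 1.0-fold higher number from compound 1 to compound 2 (0.01 log units; within the scatter) lies within the scatter, so the two compounds cannot be told apart. Compound 3, `CCCCCNC(=O)Nc1ccc(S(=O)(=O)Oc2ccccc2C(C)C)cc1`, arises from compound 2 by the change (pentylamino in place of 2-chloroethyl on a carbonyl carbon). Among the measured compounds shown here, no measured step touches this carbonyl position; the only step in hand, a 1.0-fold higher number from compound 1 to compound 2 (0.01 log units; within the scatter), altered the saturated chain and left the number essentially where it was. Nothing therefore points to a shift beyond the scatter, and compound 3 is expected to give 6000 nM (range 2500 nM to 15000 nM), a step of a 1.1-fold lower number from compound 2 to compound 3 (0.03 log units; within the scatter).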

Compound 3, half-maximal inhibitory concentration: 4700 nM
For compound 3 the middle estimate is 1.3-fold (0.11 log units) above the measured one; the measured number falls inside the stated range.
By their numbers in this assay, from the lowest: compounds 3, 1 and 2 (each within the scatter of the next).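

At this carbonyl carbon, pentylamino in place of 2-chloroethyl gives a 1.4-fold lower number from compound 2 to compound 3 (0.14 log units; within the scatter) in this assay. Pentylamino in place of pentyl, which isolates the added nitrogen while the five-carbon chain stays, gives a 1.3-fold lower number from compound 1 to compound 3 (0.13 log units; within the scatter) and so also fails to separate the compounds. No information here explains these results.

The compounds shown leave open whether a butyl or longer chain on that nitrogen, a phenyl ring there, or a carboxylic acid or amine at the chain end would move the number beyond the scatter.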